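A few compounds are considered here, and "the series" means these few. Any claim that something is new, unique, unknown or untested is made for them only; others in the source may bear on it.

Compound 2 `COc1ccc(-c2c(S(=O)(=O)c3ccc(F)cc3)cnc3c(F)cccc23)cc1` in an ADME assay on microsomes from liver (Homo sapiens) for metabolic stability, tested at 2.5 uM (a higher number here means faster removal of the compound, a lower number slower removal), gives 2.41 mL/min; its only comparator, compound 1 `O=S(=O)(c1ccc(F)cc1)c1cnc2c(F)cccc2c1-c1cccc(Cl)c1`, gives 1.21 mL/min, and the two numbers lie within the scatter of each other. Among the measured compounds shown here, the single measured step, a 2.0-fold higher number from compound 1 to compound 2 (0.30 log units; within the scatter), concerns the aryl on the aromatic carbon and not the sulfonyl side, so it offers no direct precedent for compound 3 `COc1ccc(-c2c(S(=O)(=O)c3ccc(C)c(F)c3)cnc3c(F)cccc23)cc1`, which differs from compound 2 by 3-fluoro-4-methylphenyl in place of 4-fluorophenyl on a sulfonyl sulfur. With no guide from the series for a change on the sulfonyl sulfur, no step beyond the scatter is expected, and a 1.0-fold lower number from compound 2 to compound 3 (0.00 log units; within the scatter) is the estimated shift in this assay. Compound 3 is therefore expected at 2.4 mL/min, in the range 1.2 mL/min to 4.8 mL/min.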

Compound 3, intrinsic clearance in a liver preparation (reported as CLH), per the amount of preparation that the assay uses: 3.27 mL/min
The estimate for compound 3 lay 1.4-fold (0.13 log units) below the measured number; the measured number falls inside the stated range.
By their numbers in this assay, from the lowest: compounds 1, 2 and 3 (each within the scatter of the next, the first and the last beyond it).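

In this assay, 3-fluoro-4-methylphenyl in place of 4-fluorophenyl on a sulfonyl sulfur gives a 1.4-fold higher number from compound 2 to compound 3 (0.13 log units; within the scatter). Among the compounds shown here, this is the first step read at the sulfonyl side of the series, and it stays within the scatter, as did the earlier change on the aromatic carbon. Nothing measured here bears on the reason for this small step. Still open, as far as these compounds go, is whether an amine or a carboxylic acid on the sulfonyl aryl would give a step beyond the scatter. Also open, from the compounds shown here alone, is whether the same exchange reads alike with the 3-chlorophenyl of compound 1.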